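Trifluoromethyl for methoxy on a dichloroacetanilide

The source may report more compounds than this note shows. Statements on the series, on what has been measured and on what is new or still open speak of the compounds shown alone.

Compound 1 `O=C(Nc1cccc(I)c1)C(Cl)Cl`: 4760 nM
Compound 2 `COc1cccc(NC(=O)C(Cl)Cl)c1`: 25800 nM

Within the data shown here, in a functional assay on A549 cells (Homo sapiens) for antiproliferative activity, read by MTT assay, with a stated time of 72 h (on this read-out higher numbers stand for weaker inhibition and lower numbers for stronger inhibition), compound 2 gives 25800 nM, the higher of the two numbers measured so far. Among the measured compounds shown here, the only measured step is a 5.4-fold higher number from compound 1 to compound 2 (0.73 log units; beyond the scatter), so compound 1, with 4760 nM, sits well apart from compound 2. Compound 3 `O=C(Nc1cccc(C(F)(F)F)c1)C(Cl)Cl` differs from compound 2 by trifluoromethyl in place of methoxy on an aromatic carbon, on an aromatic carbon of a six-membered aromatic ring of carbon only, meta to a group of 6 heavy atoms. For the measured compounds named here, no measured step covers trifluoromethyl directly; the only bearing comes from the step from compound 1 to compound 2, which shows that exchanging the group at this carbon can move this assay beyond the scatter. Compound 3 is therefore expected to give a lower number than compound 2, by about a 3.7-fold lower number from compound 2 to compound 3 (0.57 log units; beyond the scatter), with wide uncertainty. The estimate for compound 3 is 7000 nM, within 2500 nM to 20000 nM.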

Compound 3, half-maximal inhibitory concentration: 12200 nM
Compound 3: middle estimate off by 1.7-fold (0.24 log units), on the low side; the range from low to high includes it.
By their numbers in this assay, from the lowest: compound 1; then compound 3; then compound 2.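

In this assay, replacing methoxy with trifluoromethyl gives a 2.1-fold lower number from compound 2 to compound 3 (0.33 log units; beyond the scatter), while replacing iodo with trifluoromethyl gives a 2.6-fold higher number from compound 1 to compound 3 (0.41 log units; beyond the scatter). Trifluoromethyl therefore falls between the two groups seen earlier, and both modest steps lie beyond the scatter, so this position separates all three groups from one another, with iodo giving the lowest number and methoxy the highest. The material offers no evidence on why the groups fall in this order.

From the compounds shown here alone, whether an amine, a carboxylic acid or a nitrile on this aromatic carbon would fall inside this span of numbers or outside it remains open. Going by these compounds, it is also open whether the same order of iodo, trifluoromethyl and methoxy would hold on a different core.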